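The source may hold more compounds than are shown below. What is called first, only, known or untested is meant among the compounds shown, and "the series" means these compounds.

Measured compounds:
compound 1, `Cc1ccc(C(=O)Nc2nc3ccc(NC(=O)CSc4ccc(Cl)cc4)cc3s2)cc1`, gives 3190 nM
compound 2, `O=C(CSc1ccc(Cl)cc1)Nc1ccc2nc(NC(=O)c3ccc(C(F)(F)F)cc3)sc2c1`, gives 2890 nM
compound 3, `O=C(CSc1cccc(O)c1)Nc1ccc2nc(NC(=O)c3ccc(C(F)(F)F)cc3)sc2c1`, gives 630 nM

All three were tested in a functional assay on U2OS cells (Homo sapiens) for antiproliferative activity, read by MTT assay, with a stated time of 72 h; a lower number here means a stronger inhibitor, a higher number a weaker inhibitor. Compound 1 and compound 2 share a core and differ only in that one change: methyl in place of trifluoromethyl on an aromatic carbon. That change made a 1.1-fold higher number from compound 2 to compound 1 (0.04 log units; within the scatter), so the two compounds cannot be told apart on this read-out.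

Compound 3 is built from compound 2 by a change at the other end of the molecule: 3-hydroxyphenyl in place of 4-chlorophenyl on a sulfur. This change made a 4.6-fold lower number from compound 2 to compound 3 (0.66 log units; beyond the scatter), and compound 3 stands with the lowest number of the three measured.

Compound 4, `Cc1ccc(C(=O)Nc2nc3ccc(NC(=O)CSc4cccc(O)c4)cc3s2)cc1`, has not yet been measured. It relates to compound 3 in the same way that compound 1 relates to compound 2: methyl in place of trifluoromethyl on an aromatic carbon. The place of the change reads the same in both pairs, so this is the same change. The cores of the two pairs differ as described under the change from compound 2 to compound 3.

Compound 4 is therefore expected to show a 1.1-fold higher number from compound 3 to compound 4 (0.05 log units; within the scatter), because the same change earlier gave a 1.1-fold higher number from compound 2 to compound 1 (0.04 log units; within the scatter). Compound 4 is estimated to give about 700 nM in this assay, with a likely range from 300 nM to 1600 nM. Whether the change behaves the same way on the new core is what the measurement will tell.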

Compound 4, half-maximal inhibitory concentration: 12400 nM
The estimate for compound 4 lay 18-fold (1.25 log units) below the measured number, outside the stated range (above it).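

In this assay, methyl in place of trifluoromethyl gave a 20-fold higher number from compound 3 to compound 4 (1.29 log units; beyond the scatter) on the core carrying 3-hydroxyphenyl, so this change did not carry over from the core carrying 4-chlorophenyl: the same change on two cores in this assay, a 1.1-fold higher number (0.04 log units; within the scatter) from compound 2 to compound 1 and a 20-fold higher number (1.29 log units; beyond the scatter) from compound 3 to compound 4, 18-fold (1.25 log units) apart, beyond the scatter of two such steps

The change at the other end of the molecule, 3-hydroxyphenyl in place of 4-chlorophenyl on a sulfur, went the opposite way once methyl replaced trifluoromethyl, giving a 3.9-fold higher number from compound 1 to compound 4 (0.59 log units; beyond the scatter): the same change on two cores in this assay, a 4.6-fold lower number (0.66 log units; beyond the scatter) from compound 2 to compound 3 and a 3.9-fold higher number (0.59 log units; beyond the scatter) from compound 1 to compound 4, 18-fold (1.25 log units) apart, beyond the scatter of two such steps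

Across these four compounds, then, the effect of a change at one end depends on the group at the other end, and the two changes cannot simply be added together; this does not show why they interact, nor how either change would behave on any further core.

The compounds shown leave open whether the low number of compound 3 depends on trifluoromethyl in particular, or whether another group in its place, such as chlorine or a nitrile, would give the same result. Also open, going by these compounds, is whether the hydroxyl itself matters, which a methoxy group or an amine in its place could test on both the trifluoromethyl and the methyl compounds.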